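Halogen swap on the saturated ring carbon

A few compounds are considered here, and "the series" means these few. Any claim that something is new, unique, unknown or untested is made for them only; others in the source may bear on it.

Compound 3 `COc1cc(C2=NN(C(C)=O)C(c3ccc(Cl)c(Cl)c3)O2)cc(OC)c1OC` gives -0.8% in a functional assay on BGC-823 cells (Homo sapiens) for antiproliferative activity, read by MTT assay, tested at 1 uM; a higher number here means a stronger effect of the compound at the concentration tested, a lower number a weaker effect. Among the three measured compounds it stands second highest, but compound 1 `COc1cc(C2=NN(C(C)=O)C(c3c(Cl)cccc3Cl)O2)cc(OC)c1OC` at -1.4% and compound 2 `COc1cc(C2=NN(C(C)=O)C(c3cc(Cl)cc(Cl)c3)O2)cc(OC)c1OC` at 0% both lie within the scatter of it: a number 0.6 percentage points higher from compound 1 to compound 3 (within the scatter) and a number 0.8 percentage points lower from compound 2 to compound 3 (within the scatter), as does a number 1.4 percentage points higher from compound 1 to compound 2 (within the scatter). Compound 4 `COc1cc(C2=NN(C(C)=O)C(c3ccccc3F)O2)cc(OC)c1OC` carries 2-fluorophenyl in place of 3,4-dichlorophenyl on a saturated ring carbon. For the measured compounds named here, every measured step exchanges one dichlorophenyl pattern for another on the same saturated ring carbon, and none moves the read-out beyond the scatter; a change to 2-fluorophenyl has no direct precedent, yet nothing suggests an effect at this concentration. For compound 4 no step beyond the scatter is expected: a number 0.8 percentage points higher from compound 3 to compound 4 (within the scatter). Compound 4 is estimated at 0%, ranging from -8% to 8%.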

Compound 4, a percentage reported as inhibition, at one concentration (the size of the read-out at that concentration, not a potency): 29.6%
Compound 4: middle estimate off by 29.6 percentage points, on the low side; measured number above the stated range.
By their numbers in this assay, from the lowest: compounds 1, 3 and 2 (each within the scatter of the next); then compound 4.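

This position is not silent in this assay: the dichlorophenyl patterns stay level with one another, whereas 2-fluorophenyl gives a number 30.4 percentage points higher from compound 3 to compound 4 (beyond the scatter) and a number 29.6 percentage points higher from compound 2 to compound 4 (beyond the scatter) and a number 31 percentage points higher from compound 1 to compound 4 (beyond the scatter) as steps beyond the scatter. The change swaps two chlorine atoms for one fluorine, so a single substitution on this aryl ring can carry the read-out clear of the dichlorophenyl compounds. No evidence at hand bears on the origin of this step.

On these data alone, whether fluorine itself or the loss of the second halogen matters stays open, and a monochlorophenyl, an unsubstituted phenyl or a difluorophenyl group would separate the two. As far as these compounds go, whether an aminophenyl group at this carbon would behave like 2-fluorophenyl also stays open.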